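This account rests on a few compounds, and the source may have more. Where it says the series, first, only, none or still open, it means among the compounds named here.

Measured so far in a functional assay on the whole organism (strain Wistar) for inhibition, with Rattus norvegicus as the target, read by paw edema, with a stated time of 6 h, at a dose of 100 mg/kg; a higher number here means more inhibition at the dose given (going by the name of the read-out), a lower number less inhibition: compound 1 `COc1cc2c(cc1OC)C(CC(=O)Nc1cccc(Cl)c1)CC2` gives 38.9%; compound 2 `COc1cc2c(cc1OC)C(CC(=O)Nc1ccc(Cl)cc1)CC2` gives 61.1%; compound 3 `COc1cc2c(cc1OC)C(CC(=O)Nc1ccc(C)cc1)CC2` gives 37%.

Compound 3 has the lowest of the three numbers, but compound 1 sits within the usual scatter of it, a number 1.9 percentage points lower from compound 1 to compound 3 (within the scatter), so those two cannot be ordered; only compound 2 stands clearly apart, a number 24.1 percentage points lower from compound 2 to compound 3 (beyond the scatter). The next compound, compound 4 `COc1cc2c(cc1OC)C(CC(=O)Nc1ccccn1)CC2`, carries the change (pyridin-2-yl in place of 4-methylphenyl on an amide-type nitrogen). Within the data shown here, no measured step exchanges the ring on the amide-type nitrogen itself; the steps seen, a number 22.2 percentage points higher from compound 1 to compound 2 (beyond the scatter) and a number 24.1 percentage points lower from compound 2 to compound 3 (beyond the scatter), only swap groups on that ring and were modest. The change here is therefore untested, and a step of about that size in either direction, or none beyond the scatter, is equally plausible. Compound 4 is thus expected to give 40%, between 22% and 60%, meaning a number 3 percentage points higher from compound 3 to compound 4 (within the scatter).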

Compound 4, a percentage reported as inhibition, in the whole organism at one dose (the size of the read-out at that dose, not a potency): 29.6%
Estimate against measurement, compound 4: 10.4 percentage points above, within the range that was stated.
By their numbers in this assay, from the lowest: compounds 4, 3 and 1 (each within the scatter of the next); then compound 2.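

In this assay, the ring on the amide-type nitrogen itself can be exchanged for pyridin-2-yl with no step beyond the scatter from two of the earlier groups: a number 7.4 percentage points lower from compound 3 to compound 4 (within the scatter), and a number 9.3 percentage points lower from compound 1 to compound 4 (within the scatter). Against 4-chlorophenyl the same exchange gives a clear loss, a number 31.5 percentage points lower from compound 2 to compound 4 (beyond the scatter), so among these four groups only 4-chlorophenyl stands apart. No measurement shown explains why the groups compare this way.

Still open, on these data alone, is whether a 4-fluorophenyl or 4-methoxyphenyl ring would match 4-chlorophenyl. Also open, as far as these compounds go, is what a carboxylic acid on the ring, or a longer chain carrying it, would do.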